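The source may report more compounds than this note shows. Statements on the series, on what has been measured and on what is new or still open speak of the compounds shown alone.

Measured so far in a functional assay on HeLa cells (Homo sapiens) for antiproliferative activity, read by MTT assay, with a stated time of 72 h; a higher number here means a weaker inhibitor, a lower number a stronger inhibitor:
- compound 1 `COc1cc(C(=O)c2sc3ccccc3c2-c2ccc(F)cc2)cc(OC)c1OC`: 3000 nM
- compound 2 `COc1ccc(-c2c(C(=O)c3cc(OC)c(OC)c(OC)c3)sc3ccccc23)cc1`: 4200 nM
- compound 3 `COc1ccccc1-c1c(C(=O)c2cc(OC)c(OC)c(OC)c2)sc2ccccc12`: 5000 nM

On these numbers, compound 3 cannot be separated from the other two. The data show a 1.2-fold higher number from compound 2 to compound 3 (0.08 log units; within the scatter) and a 1.7-fold higher number from compound 1 to compound 3 (0.22 log units; within the scatter).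

The next compound, compound 4 `COc1ccc(-c2c(C(=O)c3cc(OC)c(OC)c(OC)c3)sc3ccccc23)c(OC)c1`, is compound 3 with one addition: methoxy in place of hydrogen on an aromatic carbon. A methoxy comes in place of a hydrogen on an aromatic carbon, meta to a methoxy group and para to a large group. This turns 2-methoxyphenyl into 2,4-dimethoxyphenyl.

Among the compounds with values here, no measured pair shows a methoxy replacing a hydrogen, so the evidence is only indirect. Two steps come closest. One is a 1.4-fold higher number from compound 1 to compound 2 (0.15 log units; within the scatter), where methoxy replaces fluoro. The other is a 1.2-fold higher number from compound 2 to compound 3 (0.08 log units; within the scatter), where 2-methoxyphenyl replaces 4-methoxyphenyl. Both are small. From the compounds shown here alone, three compounds are a thin base, but nothing among them points to a large change in this assay, so no step beyond the scatter is expected, and the direction stays open.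

The estimated step is a 1.1-fold lower number from compound 3 to compound 4 (0.05 log units; within the scatter).

For compound 4 the estimated value is 4500 nM, with an expected range from 2000 nM to 10000 nM.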

Compound 4, half-maximal inhibitory concentration: 3900 nM
The estimate for compound 4 lay 1.2-fold (0.06 log units) above the measured number, within the range that was stated.
By their numbers in this assay, from the lowest: compounds 1, 4, 2 and 3 (each within the scatter of the next).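

In this assay, a methoxy replacing a hydrogen, para to a large group and meta to a methoxy group, can now be read directly: there is a 1.3-fold lower number from compound 3 to compound 4 (0.11 log units; within the scatter) when 2-methoxyphenyl becomes 2,4-dimethoxyphenyl. The same 2,4-dimethoxyphenyl can also be reached from the 4-methoxyphenyl side, with a 1.1-fold lower number from compound 2 to compound 4 (0.03 log units; within the scatter) in this assay, so neither route to it shifts the number beyond ordinary repeat variation. Set against the 4-fluorophenyl group, 2,4-dimethoxyphenyl gives a 1.3-fold higher number from compound 1 to compound 4 (0.11 log units; within the scatter) and so remains inseparable from it, which means all four compounds now form one group in this assay whichever of these substituted phenyl rings they carry.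

Nothing measured here explains why these changes make so little difference.

From the compounds shown here alone, whether this ring would respond to a very different group, such as an amine or a carboxylic acid, stays open, since only methoxy and fluoro appear on it here. Also open, going by these compounds, is whether a change elsewhere on the shared core would move the number beyond the scatter.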